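The source may hold more compounds than are shown below. What is called first, only, known or untested is meant among the compounds shown, and "the series" means these compounds.

Measured compounds:
compound 1, `c1ccc(-c2ccncn2)c(OCC2=NCCN2)c1`: < 100000 nM
compound 2, `c1c[nH]c(-c2ccccc2OCC2=NCCN2)c1`: 6.31 nM
compound 3, `Cc1csc(-c2ccccc2OCC2=NCCN2)n1`: < 100000 nM

In a functional assay for activation of Alpha-1D adrenergic receptor (Homo sapiens), read by calcium flux (a lower number here means that less compound is needed, a higher number that more compound is needed for the effect), compound 1 gives only a limit, < 100000 nM, so where it stands on the numbers is not fixed. Compound 2 gives 6.31 nM in this assay. Compound 3 again gives only a limit, < 100000 nM. Two of the three values sit at this limit (the limit of < 100000 nM in this assay, at which 2 of the 3 values shown sit).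

The step to compound 4, `Cc1cnsc1-c1ccccc1OCC1=NCCN1`, changes the group on the shared core: 4-methyl-1,2-thiazol-5-yl in place of pyrimidin-4-yl on an aromatic carbon. The measured steps that bear on it are a step that the limit leaves unreadable from compound 1 to compound 2, a step that the two limits leave unreadable from compound 1 to compound 3 and a step that the limit leaves unreadable from compound 2 to compound 3; none has a readable size, as the values of compound 1 and compound 3 are limits. Compound 2 shows that a five-membered ring with one nitrogen can give a low value; compound 3 shows that a five-membered ring with nitrogen, sulfur and a methyl can sit at the limit. The group entering compound 4 resembles that of compound 3 more than that of compound 2.

The step that the limit leaves unreadable from compound 1 to compound 4 is therefore expected to remain unsized, with compound 4 expected to sit near the limit and a fair chance that only a limit is reported. Compound 4 is estimated at 20000 nM, within 500 nM to 100000 nM.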

Compound 4, half-maximal effective concentration: < 100000 nM
Compound 4 was reported as a limit (the forecaster's own chance of this, stated with the estimate: 60%); the middle value does not contradict the limit.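

In this assay, going by these compounds alone, compound 4 gives < 100000 nM as a limit, so no step linking it to compound 1, compound 2 or compound 3 can be read. Still open, as far as these compounds go, is how far compound 1, compound 3 and compound 4 lie from compound 2, and whether they differ from one another: the limit of < 100000 nM in this assay, at which 3 of the 4 values shown sit.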